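This account rests on a few compounds, and the source may have more. Where it says the series, first, only, none or still open, it means among the compounds named here.

Measured so far:
- compound 1 `O=c1c(-c2ccc(O)cc2)coc2cc(OCCCBr)ccc12`: 67.7%
- compound 2 `O=c1c(-c2ccc(O)cc2)coc2cc(CC3OC(CO)C(O)C(O)C3O)ccc12`: 0%

In a functional assay on mitochondria (Cricetulus griseus) for inhibition of Monoamine oxidase (Homo sapiens), tested at 0.9 uM (on this read-out lower numbers stand for a weaker effect and higher numbers for a stronger effect at the one concentration tested), compound 1 gives 67.7% and stands highest of the two numbers recorded. Its nearest neighbour is compound 2, which gives 0% in this assay, a gap beyond the scatter. For the measured compounds named here, no single-point step between measured compounds is recorded, so the two values show only that the bromo-terminated chain of compound 1 carries activity where the sugar-bearing compound 2 shows none.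

Compound 3 `O=C(O)CCCCCCCCCOc1ccc2c(=O)c(-c3ccc(O)cc3)coc2c1` is not yet measured in this assay. It differs from compound 1 as follows: 6-carboxyhexyl in place of bromo on a saturated chain carbon, three bonds along the chain from an oxygen on an aromatic ring. The chain on the oxygen of the aromatic ring is kept, its bromo end replaced by the longer carboxy-bearing chain.

Going by the values given here, with no measured step of this kind to lean on, a modest change is expected for compound 3, most likely downward but possibly none beyond the scatter, as a number 17.7 percentage points lower from compound 1 to compound 3 (beyond the scatter). Compound 3 is therefore estimated at 50%, within 20% to 75%.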

Compound 3, a percentage reported as inhibition, at one concentration (the size of the read-out at that concentration, not a potency): 85.1%
Compound 3: the middle estimate sits 35.1 percentage points below what was measured, outside the stated range (above it).
By their numbers in this assay, from the lowest: compound 2; then compound 1; then compound 3.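

In this assay the saturated chain carbon three bonds along the chain from an oxygen on an aromatic ring accepts much more than bromo: 6-carboxyhexyl in place of bromo gives a number 17.4 percentage points higher from compound 1 to compound 3 (beyond the scatter) at this position. The bromo end is therefore not needed for the effect at the one concentration tested, and a long chain ending in a carboxylic acid is accepted on the shared core. No measurement shown accounts for the rise.

As far as these compounds go, the step changes chain length and chain end together, so it remains open which of the two carries the rise. A plain alkyl chain of the same length, or an amine or methyl ester at the chain end, would separate them, while potency remains unsettled by a single-concentration read-out.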